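The compounds below may be only part of what the source reports. "The series", "measured", "known", "first", "only" and "open" are said of these compounds alone.

Working notes on the series in a functional assay on HCT-116 cells (Homo sapiens) for antiproliferative activity, read by CellTiter-Glo, with a stated time of 72 h; on this read-out lower numbers stand for stronger inhibition and higher numbers for weaker inhibition. Three variants of the aromatic group on the shared core have been measured: compound 1 (`COc1ccccc1-c1cc(/C=C/c2ccc(C(=O)NO)cc2)ccn1`) gives 8440 nM, compound 2 (`O=C(NO)c1ccc(/C=C/c2ccnc(-c3cccc(O)c3)c2)cc1`) gives 1610 nM, and compound 3 (`COc1ccc(-c2cc(/C=C/c3ccc(C(=O)NO)cc3)ccn2)cc1`) gives 3560 nM. Compound 3 therefore holds the second highest of the three numbers, with compound 2 below it and compound 1 above it, both gaps beyond the scatter.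

Compound 4 (`O=C(NO)c1ccc(/C=C/c2ccnc(-c3ccsc3)c2)cc1`) carries thiophen-3-yl in place of the 4-methoxyphenyl of compound 3, on the aromatic carbon next to the ring nitrogen: thiophen-3-yl in place of 4-methoxyphenyl on an aromatic carbon.

Among the measured compounds shown here, no measured compound has a five-membered aromatic ring here, so the available steps bear on this change only indirectly. All three exchange one phenyl variant for another at this carbon: a 5.2-fold lower number from compound 1 to compound 2 (0.72 log units; beyond the scatter), a 2.4-fold lower number from compound 1 to compound 3 (0.37 log units; beyond the scatter) and a 2.2-fold higher number from compound 2 to compound 3 (0.34 log units; beyond the scatter). Each is modest, and they run in both directions.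

A small step is therefore expected in this assay, possibly within the scatter, with a weak lean towards a lower number, as no thiophene comparison exists. The expected step is a 1.4-fold lower number from compound 3 to compound 4 (0.15 log units; within the scatter). Compound 4 is estimated at 2500 nM, with an expected range from 1000 nM to 6000 nM.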

Compound 4, half-maximal inhibitory concentration: 1910 nM
Compound 4: the middle estimate sits 1.3-fold (0.12 log units) above what was measured, and the stated range covers the measured number.
By their numbers in this assay, from the lowest: compounds 2, 4 and 3 (each within the scatter of the next, the first and the last beyond it); then compound 1.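

In this assay, a phenyl ring is not required on the aromatic carbon next to the ring nitrogen: thiophen-3-yl, a five-membered aromatic ring with 5 heavy atoms against the 8 of 4-methoxyphenyl, gives a 1.9-fold lower number from compound 3 to compound 4 (0.27 log units; within the scatter) and, against the 3-hydroxyphenyl of compound 2, a 1.2-fold higher number from compound 2 to compound 4 (0.07 log units; within the scatter). Among the compounds shown here, the one step from compound 4 that lies beyond the scatter is to the 2-methoxyphenyl variant, a 4.4-fold lower number from compound 1 to compound 4 (0.65 log units; beyond the scatter), so compound 4 falls with compound 2 and compound 3 and apart from compound 1, even though compound 2 and compound 3 are themselves separated by more than the scatter. No measurement available here gives a reason for these numbers.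

As far as these compounds go, the effect of a saturated ring such as piperidin-4-yl at this carbon remains open, as does that of a phenyl ring carrying an amine or a carboxylic acid. With thiophen-3-yl as the only five-membered ring, the compounds shown also leave open how thiophen-2-yl, furan-3-yl or a thiophene bearing a methyl group would compare.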